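This account rests on a few compounds, and the source may have more. Where it says the series, first, only, none or still open, it means among the compounds named here.

The measured compounds and their values:

compound 1, `COc1ccc(-c2csc(NC(=O)COc3ccc(C(=O)c4ccc(C)cc4)cc3C)n2)cc1`, in a functional assay on Ehrlich cells (Mus musculus) for cytotoxicity, read by trypan blue exclusion, with a stated time of 48 h (on this read-out lower numbers stand for stronger inhibition and higher numbers for weaker inhibition), compound 1 gives 19400 nM
compound 2, `COc1ccc(-c2csc(NC(=O)COc3ccc(C(=O)c4ccc(F)cc4)cc3C)n2)cc1`, in this assay compound 2 gives 5200 nM
compound 3, `Cc1cc(C(=O)c2ccccc2F)ccc1OCC(=O)Nc1nc(-c2ccccc2)cs1`, in this assay compound 3 gives 15400 nM

Compound 1 and compound 2 share one core and differ in a single spot: methyl in place of fluoro on an aromatic carbon. That change produced a 3.7-fold higher number from compound 2 to compound 1 (0.57 log units; beyond the scatter), so the methyl compound is the weaker of the two in this pair. Compound 3 has a different core; the difference between the two cores is not broken down here. Compound 3 stands close to compound 1 and both are well apart from compound 2 in this assay.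

Compound 4, `Cc1cc(C(=O)c2ccccc2C)ccc1OCC(=O)Nc1nc(-c2ccccc2)cs1`, is not yet measured. It comes from compound 3 by the change (methyl in place of fluoro on an aromatic carbon). Among the compounds with values here, this is the same kind of change as the one from compound 2 to compound 1, but not the same: in compound 1 the methyl sits para to a large group, while in compound 4 it sits ortho to a large group. The expectation for compound 4 rests on one pair only, so it carries real uncertainty. Given the step of a 3.7-fold higher number from compound 2 to compound 1 (0.57 log units; beyond the scatter), a rise in the number from compound 3 to compound 4 is expected. The place differs, and the expected rise is taken somewhat smaller, estimated as a 2.5-fold higher number from compound 3 to compound 4 (0.39 log units; beyond the scatter). Compound 4 is therefore expected at about 38000 nM in this assay, most likely between 15000 nM and 100000 nM.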

Compound 4, half-maximal inhibitory concentration: 24300 nM
For compound 4 the middle estimate is 1.6-fold (0.19 log units) above the measured one; the measured number falls inside the stated range.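

In this assay, replacing the 2-fluorophenyl group of compound 3 with the 2-methylphenyl group of compound 4 gives a 1.6-fold higher number from compound 3 to compound 4 (0.20 log units; within the scatter), so these two compounds cannot be told apart, whereas the same kind of swap on the other core gave a 3.7-fold higher number from compound 2 to compound 1 (0.57 log units; beyond the scatter). Set side by side, the two steps are no further apart than repeated measurements alone could make them: the same change on two cores in this assay, a 3.7-fold higher number (0.57 log units; beyond the scatter) from compound 2 to compound 1 and a 1.6-fold higher number (0.20 log units; within the scatter) from compound 3 to compound 4, 2.4-fold (0.37 log units) apart, within the scatter of two such steps. Within the data shown here, this shows no evidence that the core alters the effect of the change, but it does not show that the change carries over unaltered, since there are only two pairs, one step cannot be separated from scatter, and the methyl of compound 4 sits ortho to a large group while that of compound 1 sits at another place on its ring, so core and place vary together.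

The compounds shown leave open how the fluoro-to-methyl change behaves at the same place on each of the two cores, which would separate the role of the core from that of the place. They also leave open what other groups at this spot, such as a chloro group, a trifluoromethyl group or an amine, would do to cytotoxicity in this assay.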